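Fused bicyclic ureas in the rat aorta assay

The source may report more compounds than this note shows. Statements on the series, on what has been measured and on what is new or still open speak of the compounds shown alone.

Measured so far:
compound 1, `CC1(C)CC(NC(=O)Nc2ccccc2)c2cc(Br)ccc2O1`: 2300 nM
compound 2, `COc1ccccc1NC(=O)NC1CC(C)(C)Oc2ccc(Br)cc21`: limit only
compound 3, `COc1ccc(NC(=O)NC2CC(C)(C)Oc3ccc(F)cc32)cc1`: 15500 nM

In a functional assay (aorta) with Rattus norvegicus as the target (a higher number here means that more compound is needed for the effect, a lower number that less compound is needed), compound 1 gives 2300 nM. Compound 2 gives only > 10000 nM, which is a limit of the assay and not a number. Compound 3 gives 15500 nM, the higher of the two numbers; its nearest neighbour is compound 1, and the gap between them is beyond the scatter.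

Among the measured compounds shown here, the one step measured is an at least 4.3-fold higher number from compound 1 to compound 2 (0.63 log units; beyond the scatter), a change on the phenyl ring of the urea, not at the position that separates compound 3 from compound 4. That step ends at a limit, as noted in the limit of > 10000 nM in this assay, at which 1 of the 3 values shown sits.

Compound 4, `COc1ccc(NC(=O)NC2CC(C)(C)Oc3ccc(Br)cc32)cc1`, differs from compound 3 by bromo in place of fluoro on an aromatic carbon. For the measured compounds named here, no measured pair shows this exchange, so no measured step bears directly on it. Compound 1, which carries bromo at that place and an unsubstituted phenyl, gives 2300 nM, and the comparison with compound 3 mixes two changes. For compound 4 a moderately lower number than for compound 3 is therefore expected, a 2.6-fold lower number from compound 3 to compound 4 (0.41 log units; beyond the scatter), with wide uncertainty. Compound 4 is estimated at 6000 nM, between 1500 nM and 20000 nM.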

Compound 4, half-maximal effective concentration: > 10000 nM
Compound 4 gave a limit, no number (the forecaster's own chance of this, stated with the estimate: 30%); at least 1.6-fold (0.22 log units) between middle value and limit.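

In this assay, among the compounds shown here, bromo stays in place while 4-methoxyphenyl replaces the unsubstituted phenyl of the urea, giving an at least 4.3-fold higher number from compound 1 to compound 4 (0.63 log units; beyond the scatter); the earlier compounds showed a change of this kind only for 2-methoxyphenyl, as an at least 4.3-fold higher number from compound 1 to compound 2 (0.63 log units; beyond the scatter), so a methoxy on the phenyl ring now goes with a higher number at both of these places. Compound 4 gives > 10000 nM, which is a limit of the assay and not a number. The steps that end at compound 4 from compound 3 and from compound 2 cannot be read, so neither bromo against fluoro nor 4-methoxyphenyl against 2-methoxyphenyl gets a size, because these comparisons run into the limit: the limit of > 10000 nM in this assay, at which 2 of the 4 values shown sit.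

Still open, on these data alone, is whether any substituent on the phenyl ring of the urea, such as an amine or a carboxylic acid in place of methoxy, gives a number lower than that of compound 1 at 2300 nM. Also open, as far as these compounds go, is what the aromatic carbon carrying bromo or fluoro contributes on its own, which would need a pair with the same urea phenyl, or a chloro at that place.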